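The source may report more compounds than this note shows. Statements on the series, on what has been measured and on what is new or still open speak of the compounds shown alone.

Measured compounds:
compound 1 `O=c1c(CSC(=S)N2CCN(c3ccccc3)CC2)coc2ccccc12` — 7100 nM
compound 2 `CN1CCN(C(=S)SCc2coc3ccccc3c2=O)CC1` — 5900 nM
compound 3 `O=c1c(SC(=S)N2CCCC2)coc2ccccc12` — 3800 nM

In a functional assay on HeLa cells (Homo sapiens) for antiproliferative activity, read by MTT assay, with a stated time of 72 h (a lower number here means a stronger inhibitor, a higher number a weaker inhibitor), compound 2 gives 5900 nM, second highest of the three numbers, though both neighbours lie within the scatter of it: compound 1 gives 7100 nM and compound 3 gives 3800 nM. Compound 4 `O=c1c(CSC(=S)N2CCCCC2)coc2ccccc12` differs from compound 2 by piperidin-1-yl in place of 4-methylpiperazin-1-yl on a thiocarbonyl carbon. Among the measured compounds shown here, the one measured step at this position, a 1.2-fold lower number from compound 1 to compound 2 (0.08 log units; within the scatter), stayed within the scatter. For the measured compounds named here, compound 3 carries a different ring on the thiocarbonyl carbon but also a different link to the shared core, so no single step can be drawn from it. No shift beyond the scatter is therefore expected in this assay, the expected step being a 1.2-fold lower number from compound 2 to compound 4 (0.07 log units; within the scatter). Compound 4 is estimated at 5000 nM, with a range from 2500 nM to 10000 nM.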

Compound 4, half-maximal inhibitory concentration: 2300 nM
Estimate against measurement, compound 4: 2.2-fold (0.34 log units) above, and the stated range ends above it.
By their numbers in this assay, from the lowest: compounds 4, 3, 2 and 1 (each within the scatter of the next, the first and the last beyond it).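

In this assay, among the compounds shown here, the step of a 2.6-fold lower number from compound 2 to compound 4 (0.41 log units; beyond the scatter) comes with piperidin-1-yl in place of 4-methylpiperazin-1-yl on a thiocarbonyl carbon, the only step beyond the scatter at this position. The other step here a 1.2-fold lower number from compound 1 to compound 2 (0.08 log units; within the scatter) stayed within the scatter, so exchanging phenyl for methyl on the ring amine nitrogen moved little, while losing that nitrogen from the ring did move the number. No measured evidence accounts for this difference.

Still open, going by these compounds, is whether the ring nitrogen or its methyl matters. A morpholine ring or an unsubstituted piperazine on the thiocarbonyl carbon would separate the two.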